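A few compounds are considered here, and "the series" means these few. Any claim that something is new, unique, unknown or untested is made for them only; others in the source may bear on it.

Compounds measured so far:
compound 1, `COc1cc(-c2nn(-c3cccc(NC(=O)c4ccc(Cl)c(C(F)(F)F)c4)c3)cc2-c2ccncc2)ccc1Cl`, > 32500 nM
compound 2, `COc1cc(-c2nn(-c3cccc(NC(=O)Nc4ccc(Cl)c(C(F)(F)F)c4)c3)cc2-c2ccncc2)ccc1Cl`, 2480 nM

Compound 1 is `COc1cc(-c2nn(-c3cccc(NC(=O)c4ccc(Cl)c(C(F)(F)F)c4)c3)cc2-c2ccncc2)ccc1Cl`. In a functional assay on SR cells (Homo sapiens) for inhibition, read by sulforhodamine B assay, with a stated time of 48 h (a lower number here means a stronger inhibitor of growth, a higher number a weaker inhibitor of growth), compound 1 gives only a limit, > 32500 nM, not a number. Compound 2 is `COc1cc(-c2nn(-c3cccc(NC(=O)Nc4ccc(Cl)c(C(F)(F)F)c4)c3)cc2-c2ccncc2)ccc1Cl`. In this assay compound 2 gives 2480 nM, the only real number shown, so compound 2 stands alone as the one compound with a measured value. Going by the values given here, the single measured step, an at least 13-fold lower number from compound 1 to compound 2 (1.11 log units; beyond the scatter), rests on a limit at one end, (the limit of > 32500 nM in this assay, at which 1 of the 2 values shown sits), so its true size is not fixed.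

Compound 3 is `COc1cc(-c2nn(-c3cccc(NC(=O)c4ccccc4)c3)cc2-c2ccncc2)ccc1Cl`. The change is phenyl in place of (4-chloro-3-(trifluoromethyl)phenyl)amino on a carbonyl carbon. Among the compounds with values here, this undoes the one step that was measured: compound 3 is again an amide with a carbon-linked ring on the carbonyl carbon, as in compound 1, but now bare of the chloro and trifluoromethyl groups, and no step exists for that part of the change. Given the large step of an at least 13-fold lower number from compound 1 to compound 2 (1.11 log units; beyond the scatter), the expectation for compound 3 is a step back toward weaker inhibition, an 8.1-fold higher number from compound 2 to compound 3 (0.91 log units; beyond the scatter). Compound 3 is therefore estimated at 20000 nM, expected to lie between 5000 nM and 60000 nM, with a real chance that only a limit is reported.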

Compound 3, concentration for total growth inhibition: > 100000 nM
Compound 3: only a limit was reported; the forecaster's own chance of this, stated with the estimate: 40%; middle value at least 5.0-fold (0.69 log units) away from the limit.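

Putting phenyl in place of (4-chloro-3-(trifluoromethyl)phenyl)amino on the carbonyl carbon gives an at least 40-fold higher number from compound 2 to compound 3 (1.60 log units; beyond the scatter), a second large step at this place and one that again leaves compound 2 on the side of stronger inhibition of growth. In this assay compound 3 gives > 100000 nM, which is a limit and not a number, so the true size of this step is not fixed. Among the compounds shown, a ring joined directly to the carbonyl carbon now gives only a limit twice, once with the chloro and trifluoromethyl groups in compound 1 and once without them in compound 3, and the step between these two cannot be read: the limit of > 100000 nM in this assay, at which 1 of the 3 values shown sits.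

The change from compound 2 to compound 3 alters the amino link and the ring's chloro and trifluoromethyl groups together, so the compounds shown do not tell which of these matters more, and a plain phenylamino group on the carbonyl carbon would separate the two. Also open, from the compounds shown here alone, is how this place responds to other groups, such as a benzylamino group or a cyclohexylamino group.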